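A few compounds are considered here, and "the series" means these few. Any claim that something is new, unique, unknown or untested is made for them only; others in the source may bear on it.

Three compounds that share one core and differ only in the group on a saturated chain carbon bound to a triple-bonded carbon have been tested. In a functional assay on Ramos cells (Homo sapiens) for antiproliferative activity, read by CCK-8 assay, with a stated time of 48 h (on this read-out higher numbers stand for weaker inhibition and lower numbers for stronger inhibition), compound 1 `C=CC(=O)N1CCC[C@@H](n2nc(C#CCOc3ccccc3)c3c(N)ncnc32)C1` gives 8910 nM. Compound 2 `C=CC(=O)N1CCC[C@@H](n2nc(C#CCCc3ccccc3)c3c(N)ncnc32)C1` gives > 40000 nM, which is a limit of the assay and not a number. Within the data shown here, compound 3 `C=CC(=O)N1CCC[C@@H](n2nc(C#CCSc3ccccc3)c3c(N)ncnc32)C1` gives 37200 nM, a higher number than that of compound 1, the only other compound with a true number.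

Compound 4 `C=CC(=O)N1CCC[C@@H](n2nc(C#CCOc3cccc(OC)c3)c3c(N)ncnc32)C1` has not yet been measured in this assay. It departs from compound 3 as follows: 3-methoxyphenoxy in place of phenylsulfanyl on a saturated chain carbon bound to a triple-bonded carbon. In words, 3-methoxyphenoxy stands in place of phenylsulfanyl.

The most relevant measurement is a 4.2-fold higher number from compound 1 to compound 3 (0.62 log units; beyond the scatter), which was the exchange of phenoxy for phenylsulfanyl, and the change to compound 4 restores the oxygen-linked aryl group. The step of an at least 4.4-fold higher number from compound 1 to compound 2 (0.65 log units; beyond the scatter) also shows a phenoxy group giving way to a higher number, while an at least 1.0-fold lower number from compound 2 to compound 3 (0.03 log units; that floor lies within the scatter) separates the two replacements by no more than the scatter. Among the measured compounds shown here, no measured step isolates the added methoxy group.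

A modest move to a lower number is therefore expected, with the estimated step being a 4.1-fold lower number from compound 3 to compound 4 (0.62 log units; beyond the scatter). The estimate for compound 4 is 9000 nM, with an expected range from 2500 nM to 30000 nM.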

Compound 4, half-maximal inhibitory concentration: > 40000 nM
Compound 4 ended at the assay's limit; the forecaster's own chance of this, stated with the estimate: 8%; middle value at least 4.4-fold (0.64 log units) from the limit.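

In this assay, among these compounds, the oxygen-linked aryl group alone did not preserve the activity of compound 1: the result was an at least 4.4-fold higher number from compound 1 to compound 4 (0.65 log units; beyond the scatter), with methoxy in place of hydrogen on an aromatic carbon as the only change. The earlier compounds had shown only that replacing the oxygen link raised the number; this pair shows that a change on the aromatic ring of the phenoxy group can do so as well, and compound 4 therefore goes against any reading that the oxygen link is sufficient. Exchanging phenylsulfanyl for 3-methoxyphenoxy brought no readable gain, as the step is an at least 1.0-fold higher number from compound 3 to compound 4 (0.03 log units; that floor lies within the scatter), and the value of compound 4 is a limit of the assay and not a number, so the step between compound 2 and compound 4 cannot be read: the limit of > 40000 nM in this assay, at which 2 of the 4 values shown sit.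

The compounds shown leave open whether the loss belongs to methoxy in particular or would also follow from a fluorine, an amine or a carboxylic acid on the same aromatic ring. They also leave open whether a longer chain carrying the phenoxy group would give a lower number than compound 1, at 8910 nM.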